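Replacing 1,1-difluoroethyl with dimethylamino

The compounds below may be only part of what the source reports. "The series", "measured", "known", "first", "only" and "open" are said of these compounds alone.

In a physicochemical assay for solubility, using the shake flask method, in phosphate buffer, at pH 7 (on this read-out higher numbers stand for higher solubility and lower numbers for lower solubility), compound 2 (`COc1ccc(-c2ccc(C(=O)O)cc2C)cc1-c1cnc(C(C)(F)F)nc1CN1C(=O)O[C@H](c2cc(C(F)(F)F)cc(C(F)(F)F)c2)[C@@H]1C`) gives 20000 nM and stands within the scatter of compound 3 (`COc1ccc(-c2ccc(C(=O)O)cc2C)cc1-c1ccc(C(F)(F)F)nc1CN1C(=O)O[C@H](c2cc(C(F)(F)F)cc(C(F)(F)F)c2)[C@@H]1C`) at 29000 nM in the same measurement. Compound 1 (`COc1ccc(-c2ccc(C(=O)O)cc2C)cc1-c1cnc(C(F)(F)F)nc1CN1C(=O)O[C@H](c2cc(C(F)(F)F)cc(C(F)(F)F)c2)[C@@H]1C`) gives 6000 nM and lies further off. Compound 4 (`COc1ccc(-c2ccc(C(=O)O)cc2C)cc1-c1cnc(N(C)C)nc1CN1C(=O)O[C@H](c2cc(C(F)(F)F)cc(C(F)(F)F)c2)[C@@H]1C`) carries dimethylamino in place of 1,1-difluoroethyl on an aromatic carbon. Among the measured compounds shown here, the only measured step at this place is a 3.3-fold higher number from compound 1 to compound 2 (0.52 log units; beyond the scatter) and it involves a different exchange, so it offers a size and no firm direction. A small downward shift is expected, with the expected step being a 1.4-fold lower number from compound 2 to compound 4 (0.15 log units; within the scatter) in this assay and no move beyond the scatter. For compound 4 the estimated value is 14000 nM with an expected range from 5000 nM to 40000 nM in this read-out.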

Compound 4, solubility: 43000 nM
The estimate for compound 4 lay 3.1-fold (0.49 log units) below the measured number, outside the stated range (above it).
By their numbers in this assay, from the lowest: compound 1; then compounds 2, 3 and 4 (each within the scatter of the next, the first and the last beyond it).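

In this assay, dimethylamino gives a 2.2-fold higher number from compound 2 to compound 4 (0.33 log units; beyond the scatter), and measured against trifluoromethyl it gives a 7.2-fold higher number from compound 1 to compound 4 (0.86 log units; beyond the scatter). Among compounds 1, 2 and 4, which differ only at this position, the group without fluorine therefore gives the highest number, and both steps lie beyond the scatter. Nothing available here accounts for this rise.

Going by these compounds, it remains open whether another amine, such as morpholine or methylamino, would match dimethylamino at this position. The same question applies to an ether such as methoxy.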